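The compounds below may be only part of what the source reports. "The series", "measured", "known", "first", "only" and "open" are said of these compounds alone.

The three measured compounds share one core, an amide-linked piperazine whose far nitrogen carries an aromatic group. In an ADME assay on RAW264.7 cells (Mus musculus) for cytotoxicity, read by MTT assay, with a stated time of 72 h, tested at 50 ug/mL (on this read-out lower numbers stand for less inhibition and higher numbers for more inhibition at the one concentration tested (going by the name of the read-out)), compound 1 `CC(=O)c1ccc(N2CCN(C(=O)c3nc4ccccc4s3)CC2)cc1` gives 62.3%, compound 2 `O=C(c1nc2ccccc2s1)N1CCN(c2ccncc2)CC1` gives 62%, and compound 3 `COc1ccccc1N1CCN(C(=O)c2nc3ccccc3s2)CC1` gives 53.4%. The three numbers lie within the usual scatter of one another, so compound 3 cannot be set apart from the other two on this read-out. Among the compounds with values here, the one single-point step among them, a number 8.6 percentage points lower from compound 2 to compound 3 (within the scatter), exchanged the aromatic group on the amine nitrogen and moved the number only within the scatter.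

Compound 4 `O=C(c1nc2ccccc2s1)N1CCN(c2ccccc2)CC1` differs from compound 3 by hydrogen in place of methoxy on an aromatic carbon. Within the data shown here, no measured pair varies the methoxy on its own; the only comparison that touches the same aromatic group, a number 8.6 percentage points lower from compound 2 to compound 3 (within the scatter), stayed within the scatter. The step of a number 1.6 percentage points higher from compound 3 to compound 4 (within the scatter) is therefore expected to stay within the scatter as well, in no particular direction. Compound 4 is estimated at 55%, with a range from 40% to 70%.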

Compound 4, a percentage reported as inhibition, at one concentration (the size of the read-out at that concentration, not a potency): 67.2%
Estimate against measurement, compound 4: 12.2 percentage points below; low and high end bracket the measured number.
By their numbers in this assay, from the lowest: compounds 3, 2, 1 and 4 (each within the scatter of the next, the first and the last beyond it).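

In this assay, within the data shown here, the change from 2-methoxyphenyl to phenyl gave the only single-place step beyond the scatter so far, a number 13.8 percentage points higher from compound 3 to compound 4 (beyond the scatter) and so showed that this aromatic carbon, ortho to a large group, is a place where one change can register on this read-out. The plain phenyl is still not set apart from the other aromatic groups on the same nitrogen, since a number 5.2 percentage points higher from compound 2 to compound 4 (within the scatter) and a number 4.9 percentage points higher from compound 1 to compound 4 (within the scatter) both stay within the scatter. Nothing available bears on why the number moved at the methoxy position.

As far as these compounds go, it remains open whether the step is specific to methoxy or would also appear with a hydroxy, an ethoxy or a fluorine on the same aromatic carbon. From the compounds shown here alone, it is also open whether a methoxy on another carbon of that ring would give a similar number.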